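Sulfamoyl to carbamoyl in a cytotoxic series

A few compounds are considered here, and "the series" means these few. Any claim that something is new, unique, unknown or untested is made for them only; others in the source may bear on it.

In a functional assay on A549 cells (Homo sapiens) for cytotoxicity, read by MTT assay, with a stated time of 72 h (a higher number here means a weaker inhibitor, a lower number a stronger inhibitor), compound 3 `CC(=O)Nc1ccc(-c2ccnc(Nc3cccc(S(N)(=O)=O)c3)n2)cc1` gives 6600 nM and stands level with compound 1 `COc1ccc(-c2ccnc(Nc3cccc(C(N)=O)c3)n2)cc1` at 6700 nM. Compound 2 `CS(=O)(=O)c1ccc(-c2ccnc(Nc3cccc(C(N)=O)c3)n2)cc1` gives > 100000 nM and this value is a limit of the assay. Within the data shown here, the one measured step is an at least 14-fold higher number from compound 1 to compound 2 (1.17 log units; beyond the scatter) and it is large, but it swaps methoxy for methylsulfonyl and leaves sulfamoyl untouched. The change to compound 4 `CC(=O)Nc1ccc(-c2ccnc(Nc3cccc(C(N)=O)c3)n2)cc1` is carbamoyl in place of sulfamoyl on an aromatic carbon, with carbamoyl in place of sulfamoyl on an aromatic carbon as its full count. Compound 1 also carries carbamoyl and gives 6700 nM in this assay so no step beyond the scatter is expected. The expected step is a 1.2-fold higher number from compound 3 to compound 4 (0.08 log units; within the scatter) by this estimate. For compound 4 the estimated value is 8000 nM within an expected range from 2500 nM to 30000 nM.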

Compound 4, half-maximal inhibitory concentration: 33000 nM
For compound 4 the middle estimate is 4.1-fold (0.62 log units) below the measured one; measured number outside the range, above it.
By their numbers in this assay, from the lowest: compounds 3 and 1 (each within the scatter of the next); then compound 4. At a limit, above all of these: compound 2.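

Among these compounds, the first matched pair at this position, with acetamido held fixed, shows that the group here counts: carbamoyl in place of sulfamoyl gives a 5.0-fold higher number from compound 3 to compound 4 (0.70 log units; beyond the scatter). With carbamoyl held fixed, acetamido in place of methoxy gives a 4.9-fold higher number from compound 1 to compound 4 (0.69 log units; beyond the scatter), so the other substituent also moves the number. Acetamido in place of methylsulfonyl gives an at least 3.0-fold lower number from compound 2 to compound 4 (0.48 log units; beyond the scatter), but this size is only a bound: the limit of > 100000 nM in this assay, at which 1 of the 4 values shown sits.

Going by these compounds, what a carboxylic acid or an amine would give at this position stays open. So does whether the swap from sulfamoyl to carbamoyl has the same effect when methoxy replaces acetamido.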